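Swapping methoxy for anilino: what to expect of compound 4

The compounds below may be only part of what the source reports. "The series", "measured", "known", "first", "only" and "open" are said of these compounds alone.

- Compound 1 `C[C@@H]1CC[C@H]2CC3C(=O)CC[C@@]31C2(C)C`: 26000 nM
- Compound 2 `CC1=C2CC(C)(C)/C=C/[C@H](OC(=S)n3ccnc3)/C(C)=C\C3=C[C@H](C)C[C@]3(O2)C1=O`: 26000 nM
- Compound 3 `CO[C@H]1[C@@H]2C(=O)/C(C)=C\C3=C[C@H](C)C[C@@]34O[C@]2(CC1(C)C)[C@@H](C)C4=O`: 26000 nM

All of these values come from an ADME assay on Raji cells (Homo sapiens) for cytotoxicity, read by CellTiter-Glo, with a stated time of 72 h; a lower number here means that less compound is needed, a higher number that more compound is needed for the effect. Compound 3 stands at 26000 nM, level with compound 1 and compound 2 at the digits shown, so nothing separates the three beyond the scatter. Compound 3 is the starting point here. Compound 4 `C/C1=C/C2=C[C@H](C)C[C@@]23O[C@]2(CC(C)(C)[C@@H](Nc4ccccc4)[C@@H]2C1=O)[C@@H](C)C3=O` has not yet been measured.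

The change is a single swap: anilino in place of methoxy on a saturated ring carbon, (anilino in place of methoxy on a saturated ring carbon). The rest of the structure stays as it is.

For the measured compounds named here, no pair of measured compounds differs in only one place, so the data offer no measured step to borrow as a guide. The best available anchor is compound 3 at 26000 nM, and the three identical values give no sign of how this swap might act. In this assay, no shift beyond the scatter is expected, though a move towards less compound needed remains possible. The expected change is a 1.3-fold lower number from compound 3 to compound 4 (0.11 log units; within the scatter). For compound 4 the estimated value is 20000 nM, with an expected range from 6000 nM to 30000 nM.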

Compound 4, half-maximal effective concentration: 26000 nM
For compound 4 the middle estimate is 1.3-fold (0.11 log units) below the measured one; measured number inside the range.
By their numbers in this assay, from the lowest: compounds 1, 2, 3 and 4 (each within the scatter of the next).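

In this assay, for the compounds shown here, the swap of methoxy for anilino gives no change at the digits printed from compound 3 to compound 4 (within the scatter) and is the first single change that can be read in this set, since the earlier compounds offered no pair differing in one place. The saturated ring carbon of the five-membered ring can therefore carry anilino, with 7 heavy atoms, a six-membered aromatic ring of carbon only and 1 hydrogen-bond donor, in place of methoxy, with 2 heavy atoms, no ring and 0 hydrogen-bond donors, without any shift beyond the scatter in this read-out. Nothing measured alongside this result accounts for it, so the step records an outcome and offers no explanation.

Going by these compounds alone, this single step cannot show whether the position is insensitive to change in general, as it covers only one swap and one read-out. A plain amine, a carboxylic acid or a longer alkyl chain at this ring carbon remains an open case, as does an anilino carrying a further group on its aromatic ring.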